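The source may hold more compounds than are shown below. What is called first, only, known or untested is meant among the compounds shown, and "the series" means these compounds.

Compound 1 `OC[C@H]1O[C@@H](n2cnc3c(NCc4ccccc4Cl)ncnc32)[C@H](O)[C@@H]1O` carries a 2-chlorobenzyl group on the nitrogen of a shared core. In a functional assay on CCRF-CEM cells (Homo sapiens) for antiproliferative activity, with a stated time of 72 h (a lower number here means a stronger inhibitor, a higher number a weaker inhibitor), compound 1 gives 14500 nM. Two close relatives have been measured alongside it. Compound 2 `OC[C@H]1O[C@@H](n2cnc3c(NCc4ccccc4Br)ncnc32)[C@H](O)[C@@H]1O` gives 12300 nM in this assay, and compound 3 `OC[C@H]1O[C@@H](n2cnc3c(NCc4ccc(Br)cc4)ncnc32)[C@H](O)[C@@H]1O` gives 20600 nM. Among these three numbers compound 1 sits second highest, but every gap here is small: the step of a 1.2-fold lower number from compound 1 to compound 2 (0.07 log units; within the scatter) and the step of a 1.4-fold higher number from compound 1 to compound 3 (0.15 log units; within the scatter) both stay within the scatter, as does a 1.7-fold higher number from compound 2 to compound 3 (0.22 log units; within the scatter). So far, then, swapping one halogen for another or moving it around the ring has not shifted the readout beyond what repeat measurements would show.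

Compound 4 `OC[C@H]1O[C@@H](n2cnc3c(NCc4ccc(F)cc4F)ncnc32)[C@H](O)[C@@H]1O` is the next variation on this theme. Against compound 1 the change is 2,4-difluorophenyl in place of 2-chlorophenyl on a saturated chain carbon bound to a nitrogen on an aromatic ring. Among the measured compounds shown here, none of the measured steps involves fluorine or two halogens on the same ring, so no step bears directly on this change; the nearest guides are the halogen and position swaps above, all within the scatter. The expectation is therefore a step of a 1.0-fold higher number from compound 1 to compound 4 (0.01 log units; within the scatter) in this assay, not beyond the scatter. Compound 4 is estimated at 15000 nM, with a likely range from 7000 nM to 32000 nM.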

Compound 4, half-maximal inhibitory concentration: 7100 nM
Beside the measured number, compound 4's estimate is 2.1-fold (0.32 log units) above it, and the stated range covers the measured number.
By their numbers in this assay, from the lowest: compounds 4, 2, 1 and 3 (each within the scatter of the next, the first and the last beyond it).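

Unlike the earlier halogen swaps, the change to a 2,4-difluorobenzyl group moves the number in this assay beyond the scatter, though only modestly, both against the 2-chlorobenzyl compound (a 2.0-fold lower number from compound 1 to compound 4 (0.31 log units; beyond the scatter)) and against the 4-bromobenzyl compound (a 2.9-fold lower number from compound 3 to compound 4 (0.46 log units; beyond the scatter)). Against the 2-bromobenzyl compound the same change stays within the scatter (a 1.7-fold lower number from compound 2 to compound 4 (0.24 log units; within the scatter)), so the new group stands clearly apart from only two of the three earlier compounds, and even there the effect at this position is small. Nothing measured here explains the shift.

This change replaces the halogen and raises the number of halogens on the ring in a single step, so the compounds shown cannot separate the effect of fluorine from the effect of having two halogens, which a 2-fluorobenzyl or 4-fluorobenzyl group would help to do. Also open, from the compounds shown here alone, is whether a ring carrying no halogen, such as one with a methoxy group or an amine, or a longer chain in place of the benzyl carbon, would move the number further.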